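The source may hold more compounds than are shown below. What is called first, only, known or untested is meant among the compounds shown, and "the series" means these compounds.

Measured compounds in an ADME assay on LLC-MK2 cells (Macaca mulatta) for cytotoxicity, read by spectrophotometry and crystal violet staining, with a stated time of 4 days; on this read-out lower numbers stand for higher toxicity in this test and higher numbers for lower toxicity in this test:
Compound 1, `CC(C)n1ncc2c(C(=O)Nc3cccc(C(N)=O)c3)cc(-c3cccs3)nc21`, gives 25000 nM.
Compound 2, `CC(C)n1ncc2c(C(=O)Nc3ccccc3F)cc(-c3cccnc3)nc21`, gives 50000 nM.
Compound 3, `CC(C)n1ncc2c(C(=O)Nc3cccc(S(=O)(=O)N(C)C)c3)cc(-c3cccs3)nc21`, reaches only a limit of the assay, > 200000 nM.

Compound 1 and compound 2 sit within the usual scatter of each other in this assay, so no order between them can be read. Compound 3 stands apart at the limit of > 200000 nM in this assay, at which 1 of the 3 values shown sits. Among the measured compounds shown here, the one measured step that changes a single place is an at least 8.0-fold higher number from compound 1 to compound 3 (0.90 log units; beyond the scatter), a dimethylsulfamoyl in place of carbamoyl on an aromatic carbon.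

Compound 4, `CC(C)n1ncc2c(C(=O)Nc3ccccc3S(N)(=O)=O)cc(-c3cccs3)nc21`, is not yet measured. It differs from compound 1 as follows: 2-sulfamoylphenyl in place of 3-carbamoylphenyl on an amide-type nitrogen. Again a carbamoyl leaves and a sulfonyl-bearing group enters, which bears on the step from compound 1 to compound 3; a higher number, toward lower toxicity, is therefore expected in this assay, though the change of ring position and of the amide nitrogen context leaves the size uncertain. Compound 4 is estimated at 80000 nM, between 25000 nM and 200000 nM, meaning an expected 3.2-fold higher number from compound 1 to compound 4 (0.51 log units; beyond the scatter).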

Compound 4, half-maximal cytotoxic concentration: 25000 nM
The estimate for compound 4 lay 3.2-fold (0.51 log units) above the measured number; the measured number falls inside the stated range.
By their numbers in this assay, from the lowest: compounds 1, 4 and 2 (each within the scatter of the next). At a limit, above all of these: compound 3.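

In this assay, the change on the amide-type nitrogen gives no change at the digits printed from compound 1 to compound 4 (within the scatter), so the entry of a sulfonyl-bearing group at this place does not by itself go with a higher number. The step of an at least 8.0-fold higher number from compound 1 to compound 3 (0.90 log units; beyond the scatter) therefore does not hold for every sulfonyl-bearing group on this phenyl ring, and compound 4 goes against any such pattern. Compound 3 remains the only compound at a limit of the assay: the limit of > 200000 nM in this assay, at which 1 of the 4 values shown sits.

On these data alone, the step to compound 4 changes the group and its place on the ring together, so it remains open which of the two separates compound 4 from compound 3. Also open, as far as these compounds go, is how a carboxylic acid or an amine on this phenyl ring would read in this assay.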